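A few compounds are considered here, and "the series" means these few. Any claim that something is new, unique, unknown or untested is made for them only; others in the source may bear on it.

Measured so far:
compound 1, `O=C(O)CC/C=C\CC1COC(c2ccc(Cl)cc2Cl)OC1c1cccnc1` — in an assay for inhibition of prostacyclin synthase (Homo sapiens), using microsomes (a lower number here means a stronger inhibitor, a higher number a weaker inhibitor), compound 1 gives 2500 nM.
compound 2, `CC(C)(Oc1ccccc1O)C1OCC(C/C=C\CCC(=O)O)C(c2cccnc2)O1` — in this assay compound 2 gives only a limit of the assay, > 100000 nM.

Compound 2 therefore stands at the weak end of what this assay can report: its result is the limit of > 100000 nM in this assay, at which 1 of the 2 values shown sits, so no number is known for compound 2, only that it lies at that limit. Within the data shown here, compound 1 gives a number, but it differs from compound 2 at more than one place, so the two values show only that compound 1 is measurable while compound 2 is not.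

Compound 3, `CC(C)(Cc1ccccc1)C1OCC(C/C=C\CCC(=O)O)C(c2cccnc2)O1`, is not yet measured. It differs from compound 2 in a single place: benzyl in place of 2-hydroxyphenoxy on a saturated chain carbon bound to two saturated chain carbons and a saturated ring carbon. Among the measured compounds shown here, no step between two measured compounds is available to size this change, so the expectation rests on the limit alone. Because compound 2 sits at the limit of > 100000 nM in this assay, at which 1 of the 2 values shown sits, the step from compound 2 to compound 3 can only be read as a move away from that limit or as staying at it. A modest gain in this assay is expected, with an estimated step of an at least 3.3-fold lower number from compound 2 to compound 3 (0.52 log units; beyond the scatter). For compound 3 the estimate is 30000 nM, with a range from 5000 nM to 200000 nM, and a real chance that the assay again reports only a limit.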

Compound 3, half-maximal inhibitory concentration: 13000 nM
Compound 3: the middle estimate sits 2.3-fold (0.36 log units) above what was measured; the range from low to high includes it.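

Replacing 2-hydroxyphenoxy with benzyl on a saturated chain carbon bound to two saturated chain carbons and a saturated ring carbon gives an at least 7.6-fold lower number from compound 2 to compound 3 (0.88 log units; beyond the scatter) in this assay, so a group at this place can go along with measurable inhibition. From the compounds shown here alone, the true size of that step remains unknown, since compound 2 holds a limit and not a number: the limit of > 100000 nM in this assay, at which 1 of the 3 values shown sits. The second comparison concerns a saturated ring carbon, where 1-benzyl-1-methylethyl in place of 2,4-dichlorophenyl gives a 5.2-fold higher number from compound 1 to compound 3 (0.72 log units; beyond the scatter), so the inhibition measured for compound 3 remains weaker than that of compound 1.

The change from compound 2 to compound 3 removes a hydroxyl group and the oxygen joining the aromatic ring to the chain together, and the compounds shown do not separate these two parts of the change. Going by these compounds, how a plain phenoxy group, which keeps that oxygen without the hydroxyl group, or a longer chain in place of benzyl would behave in this assay remains open.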